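The source may report more compounds than this note shows. Statements on the series, on what has been measured and on what is new or still open speak of the compounds shown alone.

Compound 1 `COc1ccc(/C=C/c2nc(NCCN(C(C)C)C(C)C)c3ccccc3n2)cc1OC`: 20300 nM
Compound 2 `COc1ccc(/C=C/c2nc(NCCN3CCCCC3)c3ccccc3n2)cc1OC`: 78500 nM

These values come from a functional assay on PC-3 cells (Homo sapiens) for cytotoxicity, read by MTT assay, with stated times of 48 h and 4 h; on this read-out lower numbers stand for stronger inhibition and higher numbers for weaker inhibition. Compound 2 has the higher number of the two. Next is compound 3 `COc1ccc(/C=C/c2nc(NCCN3CCCCC3)c3cc(Cl)ccc3n2)cc1OC`, which differs from compound 2 as follows: chloro in place of hydrogen on an aromatic carbon. This is chloro in place of hydrogen on an aromatic carbon of the shared core. Going by the values given here, the only measured step, a 3.9-fold higher number from compound 1 to compound 2 (0.59 log units; beyond the scatter), is a change on the chain and does not touch this site. Among the compounds with values here, no measured pair here covers a change on the core, so the data give no direction for this change. No step beyond the scatter is therefore expected, and the estimated step is a 1.4-fold lower number from compound 2 to compound 3 (0.15 log units; within the scatter). The range is kept wide because a 3.9-fold higher number from compound 1 to compound 2 (0.59 log units; beyond the scatter) shows that one change can move this assay beyond the scatter. For compound 3 the estimated value is 55000 nM, with an expected range of 18000 nM to 130000 nM.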

Compound 3, half-maximal inhibitory concentration: 21200 nM
Beside the measured number, compound 3's estimate is 2.6-fold (0.41 log units) above it, and the stated range covers the measured number.
By their numbers in this assay, from the lowest: compounds 1 and 3 (each within the scatter of the next); then compound 2.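

In this assay, the core proves responsive to substitution: chloro in place of hydrogen gives a 3.7-fold lower number from compound 2 to compound 3 (0.57 log units; beyond the scatter). Going by these compounds alone, this is the first measured change on the shared core, and it shows that an aromatic carbon meta to a fused ring and para to a fused ring is not silent, with the single chlorine atom moving the number towards stronger inhibition while the piperidin-1-yl chain stays fixed. No measured evidence bears on the origin of this step.

From the compounds shown here alone, whether the step is specific to chloro remains open, as fluoro, bromo or methoxy on this carbon would be needed to tell. Also open, going by these compounds, is whether chloro at this carbon gives a step of similar size when the chain carries diisopropylamino instead of piperidin-1-yl.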